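Swapping a Hydroxy Group for a Longer Sulfoxide Chain

The source may report more compounds than this note shows. Statements on the series, on what has been measured and on what is new or still open speak of the compounds shown alone.

Compound 1 `CCN(CC)C(=O)Cn1c(=N)sc2cc(OC(F)(F)F)ccc21` gives 9 mg/kg in a functional assay on the whole organism with Rattus norvegicus as the target; a higher number here means that more compound is needed for the effect, a lower number that less compound is needed.
Compound 2 `CNS(=O)(=O)CCn1c(=N)sc2cc(OC(F)(F)F)ccc21` gives 4 mg/kg.
Compound 3 `N=c1sc2cc(OC(F)(F)F)ccc2n1CCO` gives 8 mg/kg.

Compound 3 stands second highest of the three numbers; compound 1 is nearest, and compound 2 furthest, both gaps within the scatter. Compound 4 `C[S+]([O-])CCCn1c(=N)sc2cc(OC(F)(F)F)ccc21` differs from compound 3 by a group of 4 heavy atoms (2 carbon, 1 oxygen, 1 sulfur; no ring) in place of one oxygen atom, on a saturated chain carbon, two bonds along the chain from an aromatic nitrogen. Going by the values given here, the steps that bear on this change are a 2.0-fold higher number from compound 2 to compound 3 (0.30 log units; within the scatter) and a 1.1-fold lower number from compound 1 to compound 3 (0.05 log units; within the scatter), both within the scatter, while a 2.3-fold lower number from compound 1 to compound 2 (0.35 log units; beyond the scatter) was modest. Changes at this position have so far moved the number only slightly, so no step beyond the scatter is expected. Compound 4 is therefore estimated at 6 mg/kg, ranging from 2.5 mg/kg to 15 mg/kg, an expected step of a 1.3-fold lower number from compound 3 to compound 4 (0.12 log units; within the scatter).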

Compound 4, dose for half-maximal effect: 2.3 mg/kg
Compound 4: the middle estimate sits 2.6-fold (0.42 log units) above what was measured, and the stated range ends above it.
By their numbers in this assay, from the lowest: compounds 4, 2, 3 and 1 (each within the scatter of the next, the first and the last beyond it).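

This position can move the number beyond the scatter in this assay: replacing hydroxy with the new sulfur-bearing group gives a 3.5-fold lower number from compound 3 to compound 4 (0.54 log units; beyond the scatter) and, against the diethylcarbamoyl side chain, gives a 3.9-fold lower number from compound 1 to compound 4 (0.59 log units; beyond the scatter). The remaining step, a 1.7-fold lower number from compound 2 to compound 4 (0.24 log units; within the scatter), stays within the scatter, so the new group and the methylsulfamoyl side chain cannot be told apart here. No measurement shown explains these steps.

As far as these compounds go, it remains open whether the sulfur-bearing group or the chain itself carries the step. A plain alkyl chain or a terminal amine would help separate the two.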